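Chromone amide series: methoxy to ethoxy step

The source may hold more compounds than are shown below. What is called first, only, known or untested is meant among the compounds shown, and "the series" means these compounds.

Compound 2 `COc1ccc(C(=O)Nc2cccc(NC(=O)COc3ccc4c(=O)ccoc4c3)c2)cc1` gives 18 nM in an assay on isolated protein for inhibition of Rho-associated protein kinase 1 (Homo sapiens), read by scintillation counting, radiometric assay and 33P incorporation, with a stated time of 40 min, in the presence of a further agent that is not named here (a lower number here means a stronger inhibitor, a higher number a weaker inhibitor), the lower of the two numbers in hand; compound 1 `CCc1ccc(C(=O)Nc2cccc(NC(=O)COc3ccc4c(=O)ccoc4c3)c2)cc1` gives 235 nM. Going by the values given here, the one measured step, a 13-fold lower number from compound 1 to compound 2 (1.12 log units; beyond the scatter), is the only bearing on the next move. Compound 3 `CCOc1ccc(C(=O)Nc2cccc(NC(=O)COc3ccc4c(=O)ccoc4c3)c2)cc1` differs from compound 2 by methyl in place of hydrogen on a saturated chain carbon bound to an oxygen on an aromatic ring. Since only the large step from compound 1 to compound 2 exists and the change here is smaller, a modest move toward a higher number is expected, within or just beyond the scatter, giving a 2.2-fold higher number from compound 2 to compound 3 (0.35 log units; beyond the scatter). For compound 3 a value of 40 nM is estimated, between 12 nM and 130 nM.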

Compound 3, half-maximal inhibitory concentration: 17 nM
Compound 3: the middle estimate sits 2.4-fold (0.37 log units) above what was measured; low and high end bracket the measured number.
By their numbers in this assay, from the lowest: compounds 3 and 2 (each within the scatter of the next); then compound 1.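

Methoxy to ethoxy gives a 1.1-fold lower number from compound 2 to compound 3 (0.02 log units; within the scatter) in this assay and so the added methyl on a saturated chain carbon bound to an oxygen on an aromatic ring leaves the number unmoved. Swapping the ethyl group for an ethoxy group gives a 14-fold lower number from compound 1 to compound 3 (1.14 log units; beyond the scatter) and so compound 2 and compound 3 stand together, well apart from compound 1. No measurement in hand speaks to the reason for either step.

As far as these compounds go, whether a longer chain on the same oxygen, such as propoxy or butoxy, holds the number stays open. So does the outcome for an amine or a carboxylic acid at this place.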